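Working notes on a dipeptidyl peptidase 9 series

The compounds below may be only part of what the source reports. "The series", "measured", "known", "first", "only" and "open" are said of these compounds alone.

Compound 1 `N[C@@H]1CCCN(c2cc(Nc3cc(Cl)ccn3)n3nccc3n2)C1` sits only at a limit of the assay in an assay on isolated protein for inhibition of Dipeptidyl peptidase 9 (Homo sapiens); on this read-out lower numbers stand for stronger inhibition and higher numbers for weaker inhibition: compound 1 gives > 50000 nM, which is a limit and not a number. Compound 2 `O=[N+]([O-])c1ccccc1Nc1cc(N2CCNCC2)nc2ccnn12` likewise sits at a limit, as compound 2 gives > 100000 nM in this assay. Both recorded values are limits, the limit of > 50000 nM in this assay, at which 1 of the 2 values shown sits, and (the limit of > 100000 nM in this assay, at which 1 of the 2 values shown sits), so compound 1 cannot be ranked against compound 2. Compound 3 `N[C@@H]1CCCN(c2cc(NCc3ccc(O)cc3)n3nccc3n2)C1` differs from compound 1 by 4-hydroxybenzyl in place of 4-chloropyridin-2-yl on a nitrogen on an aromatic ring. Within the data shown here, no measured step exists, so the expected step of a number no higher from compound 1 to compound 3 (the limit leaves the size open) is none beyond the scatter, with a limit the likeliest outcome. Compound 3 is estimated at 50000 nM, within 5000 nM to 300000 nM.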

Compound 3, half-maximal inhibitory concentration: > 50000 nM
Compound 3: no number, only a limit; the forecaster's own chance of this, stated with the estimate: 70%; the middle value sits exactly at the limit.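

Among these compounds, compound 1 and compound 3 both sit only at a limit, so no step between them can be read. The compounds shown leave open how 4-hydroxybenzyl and 4-chloropyridin-2-yl compare, and whether any group there gives a measurable value.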